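Hydroxyamino chain extension on the fluoroindole core

The source may report more compounds than this note shows. Statements on the series, on what has been measured and on what is new or still open speak of the compounds shown alone.

Measured in an assay on isolated protein (urine) for inhibition of Myeloperoxidase (Homo sapiens), with a stated time of 5 min; a lower number here means a stronger inhibitor, a higher number a weaker inhibitor:
- compound 1, `NCCCCc1c[nH]c2c(F)cccc12`: 6 nM
- compound 2, `CCCc1c[nH]c2ccc(F)cc12`: > 100 nM
- compound 3, `NCCCc1c[nH]c2ccc(C(=O)O)cc12`: "not active" (no number reported)

Compound 2 stands apart from the rest: in this assay compound 2 gives > 100 nM, which is a limit of the assay and not a number. From the compounds shown here alone, it sits at the limit of > 100 nM in this assay, at which 1 of the 3 values shown sits, so its true value is unknown beyond that bound. Compound 3 likewise has no number, and compound 1 alone gives a single figure, 6 nM.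

The next compound, compound 4, `ONCCCc1c[nH]c2ccc(F)cc12`, keeps the core of compound 2 and differs from it in one place: hydroxyamino in place of hydrogen on a saturated chain carbon, three bonds along the chain from an aromatic carbon. Among the measured compounds shown here, no measured pair in the set shows this exact change, so the size of the step is an open question. For the measured compounds named here, the step of an at least 3.3-fold lower number from compound 2 to compound 4 (0.52 log units; beyond the scatter) is expected to run toward lower numbers, beyond the usual scatter, because compound 2 starts from a limit of > 100 nM and compound 1, the only compound with a number, gives 6 nM. Compound 4 is expected at 30 nM, within a range of 8 nM to 150 nM. A further limit-only result for compound 4 in this assay cannot be ruled out.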

Compound 4, half-maximal inhibitory concentration: 11 nM
Compound 4: middle estimate off by 2.7-fold (0.44 log units), on the high side; low and high end bracket the measured number.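

Hydroxyamino in place of hydrogen on a saturated chain carbon, three bonds along the chain from an aromatic carbon, gives the first readable single-place step in the series: in this assay, an at least 9.0-fold lower number from compound 2 to compound 4 (0.95 log units; beyond the scatter). The earlier compounds offered no such pair, so this chain position had shown no sensitivity to a single change until now, and the 3-(hydroxyamino)propyl chain now sets it apart from the propyl chain on the same core. The step fixes a direction and a minimum size only, because the reading for compound 2 is a limit of the assay and not a number: the limit of > 100 nM in this assay, at which 1 of the 4 values shown sits.

From the compounds shown here alone, the full size of the step remains unknown, and so does how much of it belongs to the hydroxyamino group as a whole rather than to either of its atoms. Also open, going by these compounds, is whether a hydroxyl or a methoxyamino group on the same chain carbon, or a longer chain carrying hydroxyamino on the same core, would hold the level of compound 4 at 11 nM.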